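A few compounds are considered here, and "the series" means these few. Any claim that something is new, unique, unknown or untested is made for them only; others in the source may bear on it.

For the measured compounds named here, in an ADME assay for permeability, using PAMPA (on this read-out higher numbers stand for higher permeability and lower numbers for lower permeability), compound 2 `O=C(Nc1ccccc1Cl)c1cc(Cl)ccc1O` gives 118 10^-6 cm/s, the higher of the two actual numbers measured so far. Compound 3 `O=C(Nc1ccncc1Cl)c1cc(Cl)ccc1O` gives 31 10^-6 cm/s, a gap to compound 2 that lies beyond the usual scatter. Compound 1 `COc1ccc(C(=O)Nc2ccc([N+](=O)[O-])cc2Cl)c(O)c1` reads < 3 10^-6 cm/s, which is a limit of the assay and not a number. Compound 4 `CC(=O)Nc1ccc(NC(=O)c2cc(Cl)ccc2O)c(Cl)c1` has not yet been measured and differs from compound 2 in one place: acetamido in place of hydrogen on an aromatic carbon, with acetamido in place of hydrogen on an aromatic carbon, meta to a chloro group and para to a large group. Going by the values given here, with compound 2 at 118 10^-6 cm/s and no measured compound above it, a fall is more likely than a rise. In this assay a downward step beyond the scatter is expected, a 3.9-fold lower number from compound 2 to compound 4 (0.59 log units; beyond the scatter). For compound 4 the estimate is 30 10^-6 cm/s, with an expected range from 8 10^-6 cm/s to 90 10^-6 cm/s.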

Compound 4, apparent permeability: 87 10^-6 cm/s
Compound 4: the middle estimate sits 2.9-fold (0.46 log units) below what was measured; the range from low to high includes it.
By their numbers in this assay, from the lowest: compound 3; then compounds 4 and 2 (each within the scatter of the next). At a limit, below all of these: compound 1.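

In this assay, acetamido in place of hydrogen on this aromatic carbon, meta to a chloro group and para to a large group, gives a 1.4-fold lower number from compound 2 to compound 4 (0.13 log units; within the scatter), so the two compounds cannot be told apart on this read-out. This is the first step shown that isolates this position, and it shows that a group of 4 heavy atoms can enter here without a difference beyond the scatter. No information shown bears on why the two values stand so close. From the compounds shown here alone, whether an amine, a carboxylic acid or a longer chain at this position would also stay within the scatter of compound 2 remains open.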